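The source may hold more compounds than are shown below. What is called first, only, known or untested is meant among the compounds shown, and "the series" means these compounds.

In an assay on membranes from CHO cells for displacement of a labelled ligand from adenosine receptor A1 (Homo sapiens), read by scintillation counting, with a stated time of 60 min, tested at 1 uM (on this read-out lower numbers stand for less inhibition and higher numbers for more inhibition at the one concentration tested (going by the name of the read-out)), three compounds have been measured. Compound 1 `CC1=C(C(=O)OC(C)(C)C)C(c2ccsc2)NC(=O)N1` gives 15% there. Compound 2 `CCN(CC)C(=O)C1=C(C)NC(=O)NC1c1ccco1` gives 11%, and compound 3 `CCN(CC)C(=O)C1=C(C)NC(=O)NC1c1ccoc1` gives 15%. Compound 3 thus stands level with compound 1 at the digits shown, the two together the highest of the three numbers, and a few points apart from compound 2; the single step among them, a number 4 percentage points higher from compound 2 to compound 3 (within the scatter), is within the scatter, so none of the three can be set apart from the others.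

Compound 4 `CCN(CC)C(=O)C1=C(C)NC(=O)NC1c1ccsc1` has not been measured. It differs from compound 3 in one place: thiophen-3-yl in place of furan-3-yl on a saturated ring carbon. Among the measured compounds shown here, no measured pair exchanges a furan for a thiophene, so no step speaks directly to this change. For the measured compounds named here, the one related step, a number 4 percentage points higher from compound 2 to compound 3 (within the scatter), exchanged furan-2-yl for furan-3-yl and stayed within the scatter. Compound 1 also carries a thiophen-3-yl group, though the rest of its structure differs, and gives 15%, level with compound 3. On this basis compound 4 is expected to stay near compound 3, with a step of no change at the digits printed from compound 3 to compound 4 (within the scatter) of no size beyond the scatter. Compound 4 is therefore estimated at 15%, with a range from 5% to 27%.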

Compound 4, a percentage reported as inhibition, at one concentration (the size of the read-out at that concentration, not a potency): 11%
Estimate against measurement, compound 4: 4 percentage points above; the measured number falls inside the stated range.
By their numbers in this assay, from the lowest: compounds 2, 4, 1 and 3 (each within the scatter of the next).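

Read directly for the first time in this assay, thiophen-3-yl in place of furan-3-yl on the saturated ring carbon gives a small step (a number 4 percentage points lower from compound 3 to compound 4 (within the scatter)), and thiophen-3-yl in place of furan-2-yl gives none at the digits printed (no change at the digits printed from compound 2 to compound 4 (within the scatter)). Among the compounds shown here, with thiophen-3-yl held constant, diethylamino in place of tert-butoxy on the carbonyl carbon offers a first reading at a second place (a number 4 percentage points lower from compound 1 to compound 4 (within the scatter)). None of these steps separates the four compounds, so these five-membered aromatic rings and these two carbonyl groups cannot be told apart here, and no measurement is available to explain the small differences.

As far as these compounds go, what a phenyl ring or a longer alkyl chain on the saturated ring carbon would give remains open. So does the result of a carboxylic acid in place of the diethylamino or tert-butoxy group.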